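From phenoxy to allyloxy on a shared core

The compounds below may be only part of what the source reports. "The series", "measured", "known", "first", "only" and "open" are said of these compounds alone.

- Compound 1 `C=CCOc1ncnc2[nH]cnc12`: 44700 nM
- Compound 2 `Clc1ccc(Sc2ncnc3c2ncn3C2COc3ccccc3CO2)c(Cl)c1`: 12000 nM
- Compound 3 `c1ccc(Oc2ncnc3ncn(C4COc5ccccc5CO4)c23)cc1`: 21100 nM

In a functional assay on MCF7 cells (Homo sapiens) for antiproliferative activity, read by sulforhodamine B assay, with a stated time of 3 days (a lower number here means a stronger inhibitor, a higher number a weaker inhibitor), compound 3 at 21100 nM lies within the scatter of compound 2, and beyond the scatter below compound 1. Compound 4 `C=CCOc1ncnc2ncn(C3COc4ccccc4CO3)c12` has allyl in place of phenyl on an oxygen on an aromatic ring, phenoxy to allyloxy (allyl in place of phenyl on an oxygen on an aromatic ring). Among the compounds with values here, no measured pair shows this exchange, so the guide is indirect. Compound 1, which also carries allyloxy, gives 44700 nM, so no large gain is foreseen. No step beyond the scatter is expected in this assay, and the expected change is a 1.2-fold higher number from compound 3 to compound 4 (0.07 log units; within the scatter). The estimate for compound 4 is 25000 nM, with an expected range of 10000 nM to 60000 nM.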

Compound 4, half-maximal inhibitory concentration: 20900 nM
Estimate against measurement, compound 4: 1.2-fold (0.08 log units) above; the measured number falls inside the stated range.
By their numbers in this assay, from the lowest: compounds 2, 4 and 3 (each within the scatter of the next); then compound 1.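

In this assay, within the data shown here, replacing phenyl with allyl on this oxygen gives a 1.0-fold lower number from compound 3 to compound 4 (0.00 log units; within the scatter), the only measured pair to show this exchange. At this position, then, a group of six carbon atoms with an aromatic ring and a group of three carbon atoms with no ring leave the two compounds within the scatter of each other. The data offer no measured basis for explaining this result. The compounds shown leave open how an amine or a longer chain would read on this oxygen.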